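Amide nitrogen substituent and chromatographic lipophilicity in the series

The compounds below may be only part of what the source reports. "The series", "measured", "known", "first", "only" and "open" are said of these compounds alone.

Of the compounds shown here, three sharing one core have been measured. Compound 1 `COc1ccc2nc(C)cc(OCC(=O)Nc3ccc(F)cc3)c2c1` carries 4-fluorophenyl on the amide-type nitrogen; in a physicochemical assay for lipophilicity, read by HPLC, in phosphate buffer, measured as chromatographic lipophilicity, at pH 7.4 (on this read-out lower numbers stand for lower lipophilicity and higher numbers for higher lipophilicity), compound 1 gives 4.49. Compound 2 `COc1ccc2nc(C)cc(OCC(=O)Nc3c(C)cncc3C)c2c1` gives 3.01 and compound 3 `COc1ccc2nc(C)cc(OCC(=O)Nc3nccs3)c2c1` gives 3.2, which is the second highest of the three numbers; its nearest neighbour is compound 2, its furthest compound 1. The steps from compound 1 are both large: a number 1.48 log units lower from compound 1 to compound 2 (beyond the scatter) and a number 1.29 log units lower from compound 1 to compound 3 (beyond the scatter). Between the two heteroaryl amides the difference is small, a number 0.19 log units higher from compound 2 to compound 3 (within the scatter).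

Compound 4 `COc1ccc2nc(C)cc(OCC(=O)NNC(=O)c3ccncc3)c2c1` is the next change from compound 3: ((pyridin-4-yl)carbonyl)amino in place of 1,3-thiazol-2-yl on an amide-type nitrogen. Among the measured compounds shown here, no measured step covers a group of this kind on the amide-type nitrogen, so the expectation rests on indirect points only. Replacing 4-fluorophenyl by either heteroaryl group lowered the number, as in a number 1.29 log units lower from compound 1 to compound 3 (beyond the scatter), and compound 2, whose group also holds a six-membered ring with one hetero atom, stands at 3.01. A further step down from compound 3 is therefore expected, estimated as a number 1.00 log units lower from compound 3 to compound 4 (beyond the scatter). For compound 4 the expected value is 2.2, with a range from 1.5 to 2.9.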

Compound 4, distribution coefficient: 1.48
Beside the measured number, compound 4's estimate is 0.72 log units above it; the whole stated range lies above it.
By their numbers in this assay, from the lowest: compound 4; then compounds 2 and 3 (each within the scatter of the next); then compound 1.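

In this assay, among the compounds shown here, the amide-type nitrogen covers a much wider span than the earlier compounds showed (a number 3.01 log units lower from compound 1 to compound 4 (beyond the scatter)), and the two heteroaryl amides no longer mark the low end of the series (a number 1.72 log units lower from compound 3 to compound 4 (beyond the scatter); a number 1.53 log units lower from compound 2 to compound 4 (beyond the scatter)). Unlike 1,3-thiazol-2-yl, the entering ((pyridin-4-yl)carbonyl)amino group has a double bond outside aromatic rings and a hydrogen-bond donor, so the lowest number in the series comes with a change in the kind of group on this nitrogen, not only with a change of ring. No measurement shown accounts for the size of this fall.

The compounds shown do not separate the share of the carbonyl and amino link from that of the pyridin-4-yl ring, since both enter together. From the compounds shown here alone, a benzoylamino group on the same nitrogen would isolate the ring, while an acetylamino group would test the link alone, and the response to an amine or a carboxylic acid at the end of a longer chain here remains open.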